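A Pyrrolidine Amide Replaces a Cyclopropylmethyl Amide

The compounds below may be only part of what the source reports. "The series", "measured", "known", "first", "only" and "open" are said of these compounds alone.

Measured so far:
- compound 1, `O=C(/C=C1\CCc2ccc(F)cc21)NCC1CC1`: 0%
- compound 2, `NC(=O)/C=C1\CCc2cc(F)cc(F)c21`: 54%
- compound 3, `O=C(/C=C1\CCc2c(F)cc(F)cc21)NC1CC1`: 38%

In a functional assay on the whole organism with Rattus norvegicus as the target, at a dose of 20 mg/kg by the oral route (a lower number here means less inhibition, a higher number more inhibition at the dose given (going by the name of the read-out)), compound 1 gives 0%, the lowest of the three numbers. Compound 3, the nearest, shows 38%, and compound 2, the furthest, shows 54%; both stand beyond the scatter above compound 1. Compounds 2 and 3 differ from compound 1 in their fluorine pattern as well as in the amide, so no single change among the measured compounds can be isolated.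

The new compound 4, `O=C(/C=C1\CCc2ccc(F)cc21)N1CCCC1`, differs from compound 1 in one place: pyrrolidin-1-yl in place of (cyclopropylmethyl)amino on a carbonyl carbon. Whether this change helps or hurts cannot be read from the three measured compounds.

With compound 1 at the floor of the read-out, the step expected a number 10 percentage points higher from compound 1 to compound 4 (within the scatter) is small and upward, likely within the scatter. For compound 4 the estimated value in this assay is 10%, in a range from 0% to 35%.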

Compound 4, a percentage reported as inhibition, in the whole organism at one dose (the size of the read-out at that dose, not a potency): 10%
For compound 4 middle estimate and measured number coincide at the digits printed, and the stated range covers the measured number.
By their numbers in this assay, from the lowest: compounds 1 and 4 (each within the scatter of the next); then compound 3; then compound 2.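

In this assay, the step is a number 10 percentage points higher from compound 1 to compound 4 (within the scatter), so at this dose the two compounds cannot be told apart. Within the data shown here, this is the first comparison here that changes one place only: on the carbonyl carbon, an open (cyclopropylmethyl)amino group with its amide hydrogen gives way to a pyrrolidin-1-yl ring without one, and neither form stands apart from the other in the read-out. No measurement is available that would explain this outcome.

The higher numbers of the other two compounds remain unexplained, since each differs from compound 1 in its fluorine pattern as well as in its amide. On these data alone, it also remains open whether a morpholin-4-yl ring or a carboxylic acid on this carbonyl carbon would give a number beyond the scatter of compound 1.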